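Lengthening a side chain at the low end of binding

This account rests on a few compounds, and the source may have more. Where it says the series, first, only, none or still open, it means among the compounds named here.

Values in an ADME assay on a cell-free system (plasma, Homo sapiens) for protein binding, using equilibrium dialysis, with a stated time of 5 h, tested at 10 uM (a higher number here means a larger unbound share of the compound, a lower number a smaller unbound share), for the measured compounds
- Compound 1 `CC[C@@H](c1ccc(C(=O)O)c(Oc2cccc(Cl)c2)c1F)N1CCC[C@H](n2cc(C)c(=O)[nH]c2=O)C1` gives 0.011
- Compound 2 `CC[C@H](c1ccc(C(=O)O)c(Oc2cccc(Cl)c2)c1F)N1CCC[C@H](n2cc(C)c(=O)[nH]c2=O)C1` gives < 0.01 which is a limit of the assay
- Compound 3 `CCC[C@H](c1ccc(C(=O)O)c(Oc2cccc(Cl)c2)c1OC)N1CCC[C@H](n2cc(C)c(=O)[nH]c2=O)C1` gives 0.034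

Of the two values that are true numbers, compound 1 has the lower at 0.011 and compound 3 the higher at 0.034 in this assay.

Compound 4 `Cc1cn([C@H]2CCCN([C@@H](CC(C)C)c3ccc(C(=O)O)c(Oc4cccc(Cl)c4)c3F)C2)c(=O)[nH]c1=O` alters compound 1 in one place, where ethyl becomes isobutyl (isopropyl in place of methyl on a saturated chain carbon, two bonds along the chain from an amine nitrogen in a ring and an aromatic carbon).

Going by the values given here, only one measured step touches that chain carbon, the step of an at least 1.1-fold lower number from compound 1 to compound 2 (0.04 log units; that floor lies within the scatter). It changes configuration alone (the fact that compounds 1 and 2 differ only in the configuration as drawn) and ends at a limit (the limit of < 0.01 in this assay, at which 1 of the 3 values shown sits), so it says nothing direct about a longer chain. Compound 3 differs from compound 1 in more than one place and offers no clean comparison.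

No step beyond the scatter is therefore expected, and a result reported only as a limit is quite possible. The expected step is a 1.2-fold lower number from compound 1 to compound 4 (0.09 log units; within the scatter). For compound 4 the estimated value is 0.009, with an expected range from 0.004 to 0.02.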

Compound 4, unbound fraction: 0.007
Compound 4: middle estimate off by 1.3-fold (0.11 log units), on the high side, and the stated range covers the measured number.
By their numbers in this assay, from the lowest: compounds 4 and 1 (each within the scatter of the next); then compound 3.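

Going from ethyl to isobutyl on this saturated chain carbon gives a 1.6-fold lower number from compound 1 to compound 4 (0.20 log units; within the scatter) in this assay, so this larger chain leaves the unbound share of the core of compound 1 within the scatter. This is the first step shown that alters the chain itself, as the only earlier step at this carbon changed its configuration alone: the fact that compounds 1 and 2 differ only in the configuration as drawn. Compound 4 gives 0.007, a true number rather than a limit, so its step shows that the unbound share at this position can still be read with an isobutyl chain.

From the compounds shown here alone, whether a longer chain, such as hexyl, would behave like isobutyl remains open. So does whether an amine or a carboxylic acid on that chain would take the unbound share beyond the scatter.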